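This account rests on a few compounds, and the source may have more. Where it says the series, first, only, none or still open, it means among the compounds named here.

Measured compounds in a functional assay on ovarian cells (Homo sapiens) for antiproliferative activity; a higher number here means a weaker inhibitor of growth, a lower number a stronger inhibitor of growth: compound 1 `Cc1cn2c(/C=N/NC(=N)N)c(-c3ccncc3)nc2s1` gives 16600 nM; compound 2 `Cc1sc2nc(-c3ccncc3)c(/C=N/NC(=N)N)n2c1C` gives 53700 nM; compound 3 `N=C(N)N/N=C/c1c(-c2ccncc2)nc2sc(Cl)cn12` gives 10200 nM.

Among these three, compound 1 stands second highest. Its nearest neighbour is compound 3, reached by a 1.6-fold lower number from compound 1 to compound 3 (0.21 log units; within the scatter); its furthest is compound 2, reached by a 3.2-fold higher number from compound 1 to compound 2 (0.51 log units; beyond the scatter). Compound 4 `Cc1cn2c(/C=N/NC(=N)N)c(-c3ccccn3)nc2s1` differs from compound 1 by pyridin-2-yl in place of pyridin-4-yl on an aromatic carbon. Among the measured compounds shown here, neither measured step touches this group: both alter the five-membered ring of the shared core, so no step bears directly on the change. With nothing to anchor a direction, the expected step from compound 1 to compound 4 is a 1.2-fold higher number from compound 1 to compound 4 (0.08 log units; within the scatter), and compound 4 is estimated at 20000 nM, within 5000 nM to 80000 nM.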

Compound 4, concentration for 50% growth inhibition: 17400 nM
Beside the measured number, compound 4's estimate is 1.1-fold (0.06 log units) above it, and the stated range covers the measured number.
By their numbers in this assay, from the lowest: compounds 3, 1 and 4 (each within the scatter of the next); then compound 2.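

In this assay, among the compounds shown here, the change at this aromatic carbon gives a 1.0-fold higher number from compound 1 to compound 4 (0.02 log units; within the scatter) and so, unlike the earlier steps on the five-membered ring of the shared core, tests the pyridine ring itself. Pyridin-2-yl and pyridin-4-yl cannot be told apart here, so this change of attachment on the pyridine ring leaves the reading within the scatter. No independent data bear on this result.

The compounds shown leave open whether pyridin-3-yl or phenyl at this carbon would read the same. They also leave open whether pyridin-2-yl would behave alike on the chloro or dimethyl versions of the core.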